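Methyl on the amide nitrogen: cytotoxicity notes

The compounds below may be only part of what the source reports. "The series", "measured", "known", "first", "only" and "open" are said of these compounds alone.

Compound 1 `CN(C)C(=O)c1ncc([N+](=O)[O-])[nH]1` and compound 2 `CNC(=O)c1ncc([N+](=O)[O-])[nH]1` share one core; compound 3 `NC(=O)c1nc([N+](=O)[O-])cn1Cc1ccc(OC(F)(F)F)cc1` carries a different core, and the difference between the two cores is not broken down here. Compound 4 `CNC(=O)c1nc([N+](=O)[O-])cn1Cc1ccc(OC(F)(F)F)cc1` is not yet measured. In a toxicity assay on HEK293 cells (Homo sapiens) for inhibition, read by resazurin assay, with a stated time of 24 h (on this read-out lower numbers stand for higher toxicity in this test and higher numbers for lower toxicity in this test), compound 1 reaches only the limit > 100000 nM. Compound 2 likewise gives only the limit > 100000 nM. Compound 3 also stops at the limit > 100000 nM. The change methyl in place of hydrogen on an amide-type nitrogen gives the step that the two limits leave unreadable from compound 2 to compound 1, unreadable because of the limit of > 100000 nM in this assay, at which 3 of the 3 values shown sit. The change methyl in place of hydrogen on an amide-type nitrogen is the same kind of change, though the amide-type nitrogen in compound 1 has a carbonyl carbon and a saturated chain carbon as other neighbours, whereas in compound 4 it has only a carbonyl carbon. For compound 4 the step is expected to be a number no higher from compound 3 to compound 4 (the limit leaves the size open), resting on compound 3 at > 100000 nM and compound 2 at > 100000 nM. Compound 4 is therefore estimated at 100000 nM, between 50000 nM and 300000 nM.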

Compound 4, half-maximal cytotoxic concentration: > 100000 nM
Compound 4: only a limit was reported; the forecaster's own chance of this, stated with the estimate: 85%; the middle value lies on the limit itself.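

The step from compound 3 to compound 4 cannot be read in this assay, because of this: the limit of > 100000 nM in this assay, at which 4 of the 4 values shown sit.

The compounds shown leave open whether methyl in place of hydrogen on an amide-type nitrogen changes toxicity in this test at all.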